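The source may report more compounds than this note shows. Statements on the series, on what has been measured and on what is new or still open speak of the compounds shown alone.

Working notes on the series. Compound 1 `CN(C)C(=O)C1CCN(c2nc(-c3cc(F)c(Cl)cc3F)nc3c2CS(=O)(=O)C3)CC1` reaches a limit of this assay, > 100000 nM, and not a number. In a physicochemical assay for solubility, with a stated time of 20 h, at pH 6.8 (on this read-out lower numbers stand for lower solubility and higher numbers for higher solubility), compound 2 `O=S1(=O)Cc2nc(-c3cc(F)c(Cl)cc3F)nc(N3CCC(CCO)CC3)c2C1` gives 23000 nM. For the measured compounds named here, the single change between the two, an at least 4.3-fold lower number from compound 1 to compound 2 (0.63 log units; beyond the scatter), is the only measured step in the set. Compound 2 thus carries the only actual number shown. Going by the values given here, the one further value, that of compound 1, is a limit, (the limit of > 100000 nM in this assay, at which 1 of the 2 values shown sits). Compound 3 `CNC(=O)C1CCN(c2nc(-c3cc(F)c(Cl)cc3F)nc3c2CS(=O)(=O)C3)CC1` differs from compound 2 by methylcarbamoyl in place of 2-hydroxyethyl on a saturated ring carbon. Among the compounds with values here, this change runs in the opposite sense to an at least 4.3-fold lower number from compound 1 to compound 2 (0.63 log units; beyond the scatter), a carbamoyl group returning in place of the hydroxyethyl chain, and no other measured step bears on it. A step of comparable size back upward is therefore expected, a 3.0-fold higher number from compound 2 to compound 3 (0.48 log units; beyond the scatter). For compound 3 a solubility of 70000 nM is estimated, within a range from 25000 nM to 200000 nM, the upper end possibly reported again only as a limit.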

Compound 3, solubility: 11000 nM
The estimate for compound 3 lay 6.4-fold (0.80 log units) above the measured number; measured number below the stated range.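

With methylcarbamoyl on the saturated ring carbon there is a 2.1-fold lower number from compound 2 to compound 3 (0.32 log units; beyond the scatter), so a carbamoyl group as such does not restore the high read-out, and two groups with equal counts of hydrogen-bond donors and acceptors still differ beyond the scatter. The larger contrast lies within the amide pair, where hydrogen in place of methyl on the amide-type nitrogen gives an at least 9.0-fold lower number from compound 1 to compound 3 (0.95 log units; beyond the scatter). The size of that step is only a bound, as the value of compound 1 is a limit and not a number: the limit of > 100000 nM in this assay, at which 1 of the 3 values shown sits.

Going by these compounds, how far compound 1 truly lies from the other two stays open. Also open, on these data alone, is how an unsubstituted carboxamide, an amine, a carboxylic acid or a longer hydroxyalkyl chain on this ring carbon would read on the shared core.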